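The compounds below may be only part of what the source reports. "The series", "measured", "known", "first", "only" and "open" are said of these compounds alone.

Series notes, shared core with a carboxymethyl-bearing pyridazinone fused to a benzene ring, linked by a methylene to a benzimidazole that carries two ring substituents.

Compound 2 `COc1cc2[nH]c(Cc3nn(CC(=O)O)c(=O)c4ccccc34)nc2cc1Cl` in a functional assay on CHO cells for antagonist activity at sphingosine 1-phosphate receptor 2 (Homo sapiens), read by GTPgammaS binding (on this read-out lower numbers stand for stronger inhibition and higher numbers for weaker inhibition), gives 241 nM. For the measured compounds named here, of the two numbers measured so far it is the higher one, but the nearest neighbour, compound 1 `O=C(O)Cn1nc(Cc2nc3cc(F)c(OCC4CC4)cc3[nH]2)c2ccccc2c1=O`, which in this assay gives 180 nM, lies within the usual scatter, so no order between the two can be read.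

Compound 3 `O=C(O)Cn1nc(Cc2nc3cc(Cl)c(OCC4CC4)cc3[nH]2)c2ccccc2c1=O` is not yet measured. It differs from compound 2 in one place: cyclopropyl in place of hydrogen on a saturated chain carbon bound to an oxygen on an aromatic ring. Going by the values given here, no step between measured compounds covers this change alone; compound 1 carries the same cyclopropylmethoxy group beside a fluorine where compound 2 and compound 3 carry chlorine, and its value sits close to compound 2. The expected step from compound 2 to compound 3 in this assay is therefore a 1.4-fold lower number from compound 2 to compound 3 (0.15 log units; within the scatter), no more than a modest move toward a lower number, likely within the scatter. Compound 3 is estimated at 170 nM, with a range from 70 nM to 420 nM.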

Compound 3, half-maximal inhibitory concentration: 25 nM
Compound 3: the middle estimate sits 6.8-fold (0.83 log units) above what was measured, outside the stated range (below it).
By their numbers in this assay, from the lowest: compound 3; then compounds 1 and 2 (each within the scatter of the next).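

In this assay, the cyclopropyl on the saturated chain carbon bound to an oxygen on an aromatic ring counts for far more than the close values of compound 1 and compound 2 suggested, with methoxy to cyclopropylmethoxy giving a 9.6-fold lower number from compound 2 to compound 3 (0.98 log units; beyond the scatter). The aromatic halogen also matters once the cyclopropylmethoxy group is present, with chloro in place of fluoro on an aromatic carbon giving a 7.2-fold lower number from compound 1 to compound 3 (0.86 log units; beyond the scatter); each single change thus moves the value beyond the scatter, and the low number depends on cyclopropylmethoxy and chloro occurring together. No measurement at hand accounts for either step.

Whether the two changes act independently stays open, as the compounds shown include no methoxy analogue carrying fluoro. Also open, from the compounds shown here alone, is how a cyclobutylmethoxy or n-propoxy group, or a bromo in place of chloro, would read.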